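Swapping Bromo for Hydroxy on the Chain

The compounds below may be only part of what the source reports. "The series", "measured", "known", "first", "only" and "open" are said of these compounds alone.

Measured compounds:
compound 1, `OCC#CCSc1cnc2ccccc2c1[Se]CC#CCO`: 4.1 ug/mL
compound 2, `C#CCSc1cnc2ccccc2c1[Se]CC#CCBr`: 1.2 ug/mL

In a functional assay on P388 cells (Mus musculus) for cytotoxicity, read by MTT assay, with a stated time of 72 h (on this read-out lower numbers stand for stronger inhibition and higher numbers for weaker inhibition), compound 2 gives 1.2 ug/mL. Compound 1 gives 4.1 ug/mL in this assay, so compound 2 has the lowest number of the two, and the gap between them lies beyond the usual scatter.

Compound 3, `C#CCSc1cnc2ccccc2c1[Se]CC#CCO`, has not yet been measured. It differs from compound 2 in one place: hydroxy in place of bromo on a saturated chain carbon bound to a triple-bonded carbon. Everything else in the shared core and the chains stays the same.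

Among the compounds with values here, no measured pair here shows this exact change on its own, so any expectation rests on the two numbers above. Compound 1, the compound carrying hydroxy rather than bromo at the chain end, sits at the higher number, and compound 3 moves toward that pattern. The step from compound 2 to compound 3 in this assay is therefore expected to be a rise of moderate size, a 2.1-fold higher number from compound 2 to compound 3 (0.32 log units; beyond the scatter), though it could also stay within the scatter. For compound 3 in this assay, the estimate is 2.5 ug/mL, with a likely range from 1.2 ug/mL to 5 ug/mL.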

Compound 3, concentration for 50% inhibition: 3.1 ug/mL
The estimate for compound 3 lay 1.2-fold (0.09 log units) below the measured number, within the range that was stated.
By their numbers in this assay, from the lowest: compound 2; then compounds 3 and 1 (each within the scatter of the next).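

In this assay, the exchange of bromo for hydroxy on a saturated chain carbon bound to a triple-bonded carbon can now be read on its own, with the rest of the structure unchanged, and it gives a 2.6-fold higher number from compound 2 to compound 3 (0.41 log units; beyond the scatter) in a step that lies beyond the scatter. The other one-place step, hydrogen in place of hydroxymethyl on a triple-bonded carbon, gives a 1.3-fold lower number from compound 1 to compound 3 (0.12 log units; within the scatter) and stays within the scatter, so among these three compounds only the exchange at the bromo position moves the number by more than repeat measurements would. No experimental information at hand accounts for the size of either step.

From the compounds shown here alone, whether bromo stands out as a group remains open, since a chloro group, an amine or a methoxy group at the same chain position could show whether other replacements give the same rise as hydroxy or stay close to bromo. Going by these compounds, it also remains open whether the exchange would give a similar step in a compound whose other chain ends in hydroxymethyl rather than hydrogen.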